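Benzyl for cyclohexenyl on compound 1

The compounds below may be only part of what the source reports. "The series", "measured", "known", "first", "only" and "open" are said of these compounds alone.

Compound 1 `O=C1NC(O)(CCn2cc(C3=CCCCC3)nn2)C(OCc2ccccc2)=C1OCc1ccccc1` was tested in a functional assay on U-937 cells (Homo sapiens) for antiproliferative activity, read by MTT assay, with a stated time of 24 h (on this read-out higher numbers stand for weaker inhibition and lower numbers for stronger inhibition), where compound 1 gives > 100000 nM; this is a limit of the assay and not a number. Compound 2 `CC(C)(C)c1ccc(-c2cn(C/C=C3\OC(=O)C(OCc4ccccc4)=C3OCc3ccccc3)nn2)cc1` in this assay gives > 100000 nM, which is again a limit. Compound 3 `Cc1ccc(-c2cn(C/C=C3\OC(=O)C(OCc4ccccc4)=C3OCc3ccccc3)nn2)cc1` in this assay gives > 100000 nM, also a limit. Among the compounds with values here, the only step between measured compounds, a step that the two limits leave unreadable from compound 2 to compound 3, is therefore unreadable, and the limit of > 100000 nM in this assay, at which 3 of the 3 values shown sit, sums up the series so far: compound 1 stands at the same limit as compounds 2 and 3, with no number to rank it against.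

Compound 4 `O=C1NC(O)(CCn2cc(Cc3ccccc3)nn2)C(OCc2ccccc2)=C1OCc1ccccc1` differs from compound 1 by benzyl in place of cyclohex-1-en-1-yl on an aromatic carbon. Within the data shown here, no measured step bears on this change; the one step available concerns a different position on a different core and gives no size in any case. Among the measured compounds shown here, nothing so far shows any compound reaching a readable number, and nothing indicates that this change would behave differently.

Compound 4 is therefore expected to stay at the limit as well, estimated at 100000 nM within a range from 30000 nM to 300000 nM. The expected step of a number no higher from compound 1 to compound 4 (the limit leaves the size open) is none beyond the scatter.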

Compound 4, half-maximal inhibitory concentration: > 100000 nM
Compound 4: only a limit was reported; the forecaster's own chance of this, stated with the estimate: 85%; the middle value sits exactly at the limit.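

In this assay compound 4 gives > 100000 nM, which is a limit of the assay and not a number. Within the data shown here, compound 1 also stands at a limit, so no step between compound 1 and compound 4 can be read. The compounds shown leave open how benzyl and cyclohex-1-en-1-yl compare, and whether any compound here reaches a readable number, since all share one result: the limit of > 100000 nM in this assay, at which 4 of the 4 values shown sit.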